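This account rests on a few compounds, and the source may have more. Where it says the series, first, only, none or still open, it means among the compounds named here.

Measured compounds in a functional assay on HCT-15 cells (Homo sapiens) for cytotoxicity, read by CCK-8 assay and cell counting, with a stated time of 2 days; a lower number here means a stronger inhibitor, a higher number a weaker inhibitor:
compound 1, `Oc1cccc(-c2cc(-c3ccc(Cl)cc3)nc(-c3cccs3)c2)c1`, gives 9280 nM;
compound 2, `Oc1ccc(-c2cc(-c3ccc(Cl)cc3)nc(-c3cccs3)c2)cc1`, gives 6470 nM;
compound 3, `Oc1ccc(-c2cc(-c3ccccc3)nc(-c3cccc(Cl)c3)c2)cc1`, gives 6100 nM.

The three values sit close together, and compound 3 against compound 2 shows no separation worth naming. The difference between the cores of compound 2 and compound 3 is not broken down here.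

One change is seen once: 3-hydroxyphenyl in place of 4-hydroxyphenyl on an aromatic carbon, which gave a 1.4-fold higher number from compound 2 to compound 1 (0.16 log units; within the scatter). Compound 4, `Oc1cccc(-c2cc(-c3ccccc3)nc(-c3cccc(Cl)c3)c2)c1`, is not yet measured; it is reached from compound 3 by 3-hydroxyphenyl in place of 4-hydroxyphenyl on an aromatic carbon. The surroundings differ: in compound 2 the place is meta to a 4-chlorophenyl group and a thiophen-2-yl group, in compound 3 meta to a 3-chlorophenyl group and a phenyl group, so this is the same kind of change, not the same.

In this assay, among the measured compounds shown here, the step is expected to be a 1.3-fold higher number from compound 3 to compound 4 (0.12 log units; within the scatter), resting on the single earlier step from compound 2 to compound 1. Compound 4 is expected at about 8000 nM, within 4500 nM to 16000 nM.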

Compound 4, half-maximal inhibitory concentration: 2550 nM
Compound 4: middle estimate off by 3.1-fold (0.50 log units), on the high side, outside the stated range (below it).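

Going from 4-hydroxyphenyl to 3-hydroxyphenyl gave a 2.4-fold lower number from compound 3 to compound 4 (0.38 log units; beyond the scatter), so the earlier step did not carry over to this core in size or in direction: the same change on two cores in this assay, a 1.4-fold higher number (0.16 log units; within the scatter) from compound 2 to compound 1 and a 2.4-fold lower number (0.38 log units; beyond the scatter) from compound 3 to compound 4, 3.4-fold (0.54 log units) apart, beyond the scatter of two such steps

On these two cores, a step read on one is therefore no safe guide to the other. Among the compounds shown here, the data do not show which difference sets the gap, the thiophen-2-yl group against the phenyl group or the 4-chlorophenyl group against the 3-chlorophenyl group, as the cores differ in both and only two pairs stand behind the comparison.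

Open, from the compounds shown here alone, is how either core responds when an amine, a carboxylic acid or a methoxy group takes the place of the hydroxyl. Also open, going by these compounds, is whether a core pairing the thiophen-2-yl group with the 3-chlorophenyl group would follow compound 4 or compound 1.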